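Halogen swap on two enone cores in L1210 inhibition

A few compounds are considered here, and "the series" means these few. Any claim that something is new, unique, unknown or untested is made for them only; others in the source may bear on it.

Measured so far:
compound 1, `O=C1/C(=C/c2cccc(Cl)c2)Cc2ccccc21`, 41200 nM
compound 2, `O=C1/C(=C/c2cccc(Br)c2)Cc2ccccc21`, 43300 nM
compound 3, `O=C1CCCCC/C1=C\c1ccc(Cl)cc1`, 83000 nM

All three values come from a functional assay on L1210 cells (Mus musculus) for inhibition; a lower number here means a stronger inhibitor, a higher number a weaker inhibitor. Compound 1 and compound 2 share one core and differ only by bromo in place of chloro on an aromatic carbon. The step of a 1.1-fold higher number from compound 1 to compound 2 (0.02 log units; within the scatter) is small, so the two values are not distinguishable here. Compound 3 carries a different core; the difference between the two cores is not broken down here. In this assay compound 3 gives 83000 nM, which sits above the other two only by an amount inside the scatter, so no order among the three can be claimed.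

Compound 4, `O=C1CCCCC/C1=C\c1ccc(Br)cc1`, is not yet measured. It relates to compound 3 by bromo in place of chloro on an aromatic carbon. For the measured compounds named here, this is the same kind of change as the one from compound 1 to compound 2, though not the same: there the place is described as meta to a large group, here as para to a group of 9 heavy atoms. Going by the values given here, both are a bromo in place of chloro on an aromatic carbon, and there is only one measured instance to go by.

The expectation for compound 4 rests on compound 3 and on the earlier step: because a 1.1-fold higher number from compound 1 to compound 2 (0.02 log units; within the scatter) was within the scatter, the estimated step of a 1.1-fold higher number from compound 3 to compound 4 (0.04 log units; within the scatter) is likewise taken as small. Compound 4 is therefore expected to give about 90000 nM in this assay, with the estimated range 45000 nM to 180000 nM; a limit rather than a number is possible given how weak compound 3 is.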

Compound 4, half-maximal inhibitory concentration: 68400 nM
Compound 4: middle estimate off by 1.3-fold (0.12 log units), on the high side; the measured number falls inside the stated range.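

In this assay, bromo in place of chloro on an aromatic carbon gives a 1.2-fold lower number from compound 3 to compound 4 (0.08 log units; within the scatter), so on this second core the swap again produces no readable difference. For the compounds shown here, the two halogen steps also do not differ from each other, so as far as these two pairs go, the near-absence of a step carries from the core of compound 1 to the core of compound 3: the same change on two cores in this assay, a 1.1-fold higher number (0.02 log units; within the scatter) from compound 1 to compound 2 and a 1.2-fold lower number (0.08 log units; within the scatter) from compound 3 to compound 4, 1.3-fold (0.11 log units) apart, within the scatter of two such steps This does not establish a rule for other cores: there are only two pairs, the halogen sits in a different place in each, so core and place cannot be separated, and neither pair shows what the swap does on a stronger inhibitor.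

The compounds shown carry only chloro or bromo on the aromatic ring, so it remains open what an amine, a carboxylic acid or a methoxy group in that place would give in this assay. Going by these compounds alone, also open is what the core alone contributes, since no pair here differs only in its core, and whether either core can support a clearly stronger inhibitor.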